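This account rests on a few compounds, and the source may have more. Where it says the series, first, only, none or still open, it means among the compounds named here.

Cytotoxicity series on a mouse macrophage line. Compound 1 `O=C(Nc1ccc(I)cc1F)c1ccccc1OCc1ccc(F)cc1F` is the reference; in an ADME assay on RAW264.7 cells (Mus musculus) for cytotoxicity, read by MTT assay, with a stated time of 24 h (a lower number here means that less compound is tolerated, a higher number that more compound is tolerated), compound 1 gives 32600 nM. Compound 2 `COc1ccc(C(=O)Nc2ccc(I)cc2F)c(OCc2ccc(F)cc2F)c1` carries one added group on the same core, (methoxy in place of hydrogen on an aromatic carbon), and in this assay compound 2 gives 36800 nM. The step is a 1.1-fold higher number from compound 1 to compound 2 (0.05 log units; within the scatter), so the added methoxy leaves tolerance essentially unchanged here.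

Compound 3 `O=C(Nc1ccc(-c2ccc(F)cc2F)cc1F)c1ccccc1O` rests on a different core; the difference between the two cores is not broken down here. In this assay compound 3 gives 28600 nM, a number that sits within the scatter of both compound 1 and compound 2, so the three measured compounds cannot be ordered.

Compound 4 `COc1ccc(C(=O)Nc2ccc(-c3ccc(F)cc3F)cc2F)c(O)c1` has not been measured. It relates to compound 3 as compound 2 relates to compound 1: methoxy in place of hydrogen on an aromatic carbon. The surroundings are not identical: in the first pair the entering group sits meta to a large group and para to a large group, whereas in the second pair it sits meta to a hydroxy group and para to a large group. It is therefore the same kind of change, not the same change.

Going by the values given here, with only one prior instance to rest on, the expected step from compound 3 to compound 4 in this assay is a 1.1-fold higher number from compound 3 to compound 4 (0.03 log units; within the scatter), essentially flat, because the earlier step of a 1.1-fold higher number from compound 1 to compound 2 (0.05 log units; within the scatter) stayed within the scatter. For compound 4 the estimate in this assay is 31000 nM, with a range from 15000 nM to 62000 nM.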

Compound 4, half-maximal cytotoxic concentration: 26300 nM
Beside the measured number, compound 4's estimate is 1.2-fold (0.07 log units) above it; the range from low to high includes it.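

In this assay, methoxy in place of hydrogen on the second core gives a 1.1-fold lower number from compound 3 to compound 4 (0.04 log units; within the scatter), which matches the flat result on the first core. Set side by side, the two steps cannot be told apart: the same change on two cores in this assay, a 1.1-fold higher number (0.05 log units; within the scatter) from compound 1 to compound 2 and a 1.1-fold lower number (0.04 log units; within the scatter) from compound 3 to compound 4, 1.2-fold (0.09 log units) apart, within the scatter of two such steps

Within these two pairs, then, the change carries from one core to the other as a step too small to read, and the opposite directions of the two steps carry no meaning. This does not show that methoxy is without consequence on every core in the series, since two pairs are a narrow base, both differ in their surroundings, and neither step lies beyond the scatter, so no real effect of the change has yet been seen to transfer.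

On these data alone, it remains open whether a group other than methoxy at this place, such as an amine, a carboxylic acid or a longer alkoxy chain, would also leave the number flat on both cores. Also open, as far as these compounds go, is whether the same holds for a core that differs from these two, and which of the differences between the two cores matters, if any does, for tolerance in this cell line.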